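Halogenated phenyl exchange on the pyrazole nitrogen, two cores

A few compounds are considered here, and "the series" means these few. Any claim that something is new, unique, unknown or untested is made for them only; others in the source may bear on it.

Measured compounds:
compound 1 `CN(C)/C=N/c1c(C=O)c(-c2ccc(Cl)cc2)nn1-c1cccc(Cl)c1` — 9200 nM
compound 2 `CN(C)/C=N/c1c(C=O)c(-c2ccc(Cl)cc2)nn1-c1ccc(Br)cc1` — 62900 nM
compound 3 `Cc1ccc(-c2cc(/N=C/N(C)C)n(-c3cccc(Cl)c3)n2)cc1` — 80900 nM

In a functional assay on NCI-H226 cells (Homo sapiens) for inhibition, read by MTT assay, with a stated time of 72 h (on this read-out higher numbers stand for weaker inhibition of growth and lower numbers for stronger inhibition of growth), compound 1 gives 9200 nM. Compound 2 differs by 4-bromophenyl in place of 3-chlorophenyl on an aromatic nitrogen, and the step is a 6.8-fold higher number from compound 1 to compound 2 (0.83 log units; beyond the scatter). Compound 3 belongs to a second core; its difference from compound 1 is not broken down here. In this assay compound 3 gives 80900 nM, and the gap between compound 3 and compound 2 lies within the scatter.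

Compound 4 `Cc1ccc(-c2cc(/N=C/N(C)C)n(-c3ccc(Br)cc3)n2)cc1` has not been measured. It differs from compound 3 by 4-bromophenyl in place of 3-chlorophenyl on an aromatic nitrogen. This is the same kind of change as that from compound 1 to compound 2, not the same: around the place, the core of compound 1 carries a 4-chlorophenyl group and a formyl group two ring bonds away, whereas the core of compound 3 carries a 4-methylphenyl group there.

For the measured compounds named here, a step of similar direction is expected, a 3.1-fold higher number from compound 3 to compound 4 (0.49 log units; beyond the scatter), resting on the single earlier step of a 6.8-fold higher number from compound 1 to compound 2 (0.83 log units; beyond the scatter) and on compound 3 already giving 80900 nM. Compound 4 is therefore expected to give 250000 nM in this assay, between 70000 nM and 700000 nM, with a real chance that only a limit is reported.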

Compound 4, concentration for 50% growth inhibition: 73900 nM
Compound 4: the middle estimate sits 3.4-fold (0.53 log units) above what was measured, within the range that was stated.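

Exchanging 3-chlorophenyl for 4-bromophenyl on the aromatic nitrogen gives a 1.1-fold lower number from compound 3 to compound 4 (0.04 log units; within the scatter) in this assay, so the size of the step does not carry over between the two cores: the same change on two cores in this assay, a 6.8-fold higher number (0.83 log units; beyond the scatter) from compound 1 to compound 2 and a 1.1-fold lower number (0.04 log units; within the scatter) from compound 3 to compound 4, 7.5-fold (0.87 log units) apart, beyond the scatter of two such steps Among these compounds, the effect of this exchange therefore depends on the core, and a step read on one core cannot simply be added to a value on the other. This does not show which difference between the cores matters, as the presence of the formyl group and the 4-chlorophenyl versus 4-methylphenyl exchange travel together, and one pair per core gives no general rule.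

Open, as far as these compounds go, is whether a core carrying both the formyl group and the 4-methylphenyl group would show the larger or the smaller step. Also open, from the compounds shown here alone, is how the same exchange on the nitrogen would behave with an amine or a carboxylic acid in place of the formyl group.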